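Fluorouracil conjugates of a sesquiterpene lactone core

The source may hold more compounds than are shown below. What is called first, only, known or untested is meant among the compounds shown, and "the series" means these compounds.

The series joins one shared core to a fluorouracil unit through linkers of differing length and kind. In a functional assay on Bel7402/5-FU cells (Homo sapiens) for antiproliferative activity, read by MTT assay, with a stated time of 72 h (a lower number here means a stronger inhibitor, a higher number a weaker inhibitor), compound 1, `C=C1C(=O)O[C@H]2[C@H]1CC/C(COC(=O)CCC(=O)OCn1cc(F)c(=O)[nH]c1=O)=C\CC[C@@]1(C)O[C@@H]21`, returns only a limit, > 20000 nM. Compound 2, `C=C1C(=O)O[C@H]2[C@H]1CC/C(COC(=O)CCC(=O)NCCCCCCNC(=O)Cn1cc(F)c(=O)[nH]c1=O)=C\CC[C@@]1(C)O[C@@H]21`, likewise returns only a limit in this assay, > 20000 nM. Among the measured compounds shown here, compound 3, `C=C1C(=O)O[C@H]2[C@H]1CC/C(COC(=O)Cn1cc(F)c(=O)n(Cc3ccc(Cl)cc3)c1=O)=C\CC[C@@]1(C)O[C@@H]21`, is the sole member with a measured number, giving 2420 nM in this assay, which sets it apart from the limit of > 20000 nM in this assay, at which 2 of the 3 values shown sit. For the measured compounds named here, compound 3 is therefore the single point of reference here, and no step between two measured compounds that differ in one place exists in this set.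

Compound 4, `C=C1C(=O)O[C@H]2[C@H]1CC/C(COC(=O)Cn1cc(F)c(=O)n(CCC)c1=O)=C\CC[C@@]1(C)O[C@@H]21`, is not yet measured. It differs from compound 3 by ethyl in place of 4-chlorophenyl on a saturated chain carbon bound to an aromatic nitrogen. The change removes the one six-membered aromatic ring of carbon only together with the chlorine and leaves a short chain on the same saturated chain carbon bound to an aromatic nitrogen. Going by the values given here, no measured pair covers such a change, so the expectation rests on compound 3 alone.

The step of a 2.5-fold higher number from compound 3 to compound 4 (0.39 log units; beyond the scatter) is expected to lie somewhat beyond the usual scatter, toward a weaker inhibitor. For compound 4 the estimated value in this assay is 6000 nM, with a range from 1500 nM to 20000 nM, and a limit rather than a number is also possible.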

Compound 4, half-maximal inhibitory concentration: 9110 nM
Beside the measured number, compound 4's estimate is 1.5-fold (0.18 log units) below it; measured number inside the range.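

In this assay, the series now has its first readable step at this place, on a saturated chain carbon bound to an aromatic nitrogen: the exchange of 4-chlorobenzyl for propyl gives a 3.8-fold higher number from compound 3 to compound 4 (0.58 log units; beyond the scatter). The loss of the aromatic ring and its chlorine therefore weakens the compound beyond the scatter, yet compound 4 still returns a measured number and does not join the values that are only a limit of the assay: the limit of > 20000 nM in this assay, at which 2 of the 4 values shown sit. The step removes the ring and the chlorine together, so this one pair cannot assign the difference to either of them alone.

The compounds shown leave open how an unsubstituted benzyl, a longer chain such as hexyl, or a chain ending in an amine would read at this place, and so whether the number follows chain length, the aromatic ring or the chlorine. They also leave open whether the same exchange gives a step of similar size when the fluorouracil unit is joined to the shared core through a different linker.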